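Cyano on the Aromatic Ring: Expectation for Compound 4

The source may hold more compounds than are shown below. What is called first, only, known or untested is meant among the compounds shown, and "the series" means these compounds.

Three compounds share one core and differ only in a single group on the six-membered aromatic ring of carbon only. Compound 1 `Cc1[nH]cnc1CN1CCN(c2cccc(Cl)c2)C1=O` carries a chloro group, compound 2 `Cc1[nH]cnc1CN1CCN(c2cccc(Br)c2)C1=O` a bromo group, and compound 3 `Cc1[nH]cnc1CN1CCN(c2ccccc2)C1=O` only hydrogen at that carbon. In a functional assay (Cavia porcellus) for antagonist activity at Serotonin 3 (5-HT3) receptor (Homo sapiens) (on this read-out higher numbers stand for weaker inhibition and lower numbers for stronger inhibition), compound 1 gives 12 nM, compound 2 gives 10.4 nM, and compound 3 gives 26.9 nM. Compound 3 therefore stands with the highest number of the three, meaning the weakest inhibition; the step of a 2.2-fold higher number from compound 1 to compound 3 (0.35 log units; beyond the scatter) and the step of a 2.6-fold higher number from compound 2 to compound 3 (0.41 log units; beyond the scatter) both go beyond the scatter, while a 1.2-fold lower number from compound 1 to compound 2 (0.06 log units; within the scatter) does not.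

Compound 4 `Cc1[nH]cnc1CN1CCN(c2cccc(C#N)c2)C1=O` arises from compound 3 by cyano in place of hydrogen on an aromatic carbon, on an aromatic carbon of a six-membered aromatic ring of carbon only. For the measured compounds named here, the only guidance comes from the chloro and bromo steps, which both lowered the number modestly when a group entered at this carbon. A cyano group is expected to act in the same direction, so the estimated step is a 1.9-fold lower number from compound 3 to compound 4 (0.28 log units; within the scatter). Compound 4 is expected to give 14 nM, with a range from 6 nM to 35 nM.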

Compound 4, antagonist equilibrium constant: 134 nM
Compound 4: the middle estimate sits 9.6-fold (0.98 log units) below what was measured, and the stated range ends below it.
By their numbers in this assay, from the lowest: compounds 2 and 1 (each within the scatter of the next); then compound 3; then compound 4.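

In this assay, a group entering at this aromatic carbon does not always lower the number: cyano in place of hydrogen gives a 5.0-fold higher number from compound 3 to compound 4 (0.70 log units; beyond the scatter) and so runs opposite to the chloro and bromo steps. Set directly against those two groups, the cyano change gives an 11-fold higher number from compound 1 to compound 4 (1.05 log units; beyond the scatter) and a 13-fold higher number from compound 2 to compound 4 (1.11 log units; beyond the scatter), which shows that at this position the identity of the entering group matters, not only whether a group is present. Nothing measured here bears on why cyano parts from chloro and bromo at this carbon.

The compounds shown leave open how other groups at this carbon would fall, such as a methoxy group, an amine or a carboxylic acid. They also leave open whether cyano would give a similar step on a different carbon of the same ring.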